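Swapping a 3,4-dihydroxyphenyl for phenyl

The source may report more compounds than this note shows. Statements on the series, on what has been measured and on what is new or still open speak of the compounds shown alone.

Measured in a functional assay, read by spectrophotometry, with a stated time of 5 min; on this read-out lower numbers stand for stronger inhibition and higher numbers for weaker inhibition:
- compound 1 `CCOc1cc(C=C(C(=O)/C=C/c2ccc(O)c(OC)c2)C(=O)/C=C/c2ccc(O)c(OC)c2)ccc1O`: 3980 nM
- compound 2 `COc1cc(/C=C/C(=O)C(=Cc2ccc(O)c(O)c2)C(=O)/C=C/c2ccc(O)c(OC)c2)ccc1O`: 2200 nM

Compound 2 and compound 1 lie within the scatter of each other, so neither stands apart. The next structure is compound 3 `COc1cc(/C=C/C(=O)C(=Cc2ccccc2)C(=O)/C=C/c2ccc(O)c(OC)c2)ccc1O`, and the change is phenyl in place of 3,4-dihydroxyphenyl on a double-bonded chain carbon bound to a double-bonded chain carbon. Among the measured compounds shown here, only one measured step bears on this, and only loosely: a 1.8-fold lower number from compound 1 to compound 2 (0.26 log units; within the scatter). It replaced ethyl with hydrogen on an oxygen on an aromatic ring and did not remove the 3,4-dihydroxyphenyl, so the direction is uncertain. The expected change is small and slightly upward, a 1.8-fold higher number from compound 2 to compound 3 (0.26 log units; within the scatter), with no firm shift beyond the scatter in this assay. For compound 3 the estimated value is 4000 nM, with an expected range of 1200 nM to 13000 nM.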

Compound 3, half-maximal inhibitory concentration: 8580 nM
Beside the measured number, compound 3's estimate is 2.1-fold (0.33 log units) below it; the measured number falls inside the stated range.
By their numbers in this assay, from the lowest: compounds 2 and 1 (each within the scatter of the next); then compound 3.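

In this assay, this place on the double-bonded chain carbon now shows a change beyond the scatter: phenyl in place of 3,4-dihydroxyphenyl gives a 3.9-fold higher number from compound 2 to compound 3 (0.59 log units; beyond the scatter) and weaker inhibition. Phenyl in place of 3-ethoxy-4-hydroxyphenyl points the same way, with a 2.2-fold higher number from compound 1 to compound 3 (0.33 log units; beyond the scatter), so the bare ring falls behind both substituted rings, which the earlier pair could not show. Nothing available here explains this loss.

Going by these compounds, whether a single hydroxyl on the ring would be enough stays open, as does how an amine or a carboxylic acid in place of the phenyl would fare.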